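Naphthyl for trifluoromethylphenyl on a caspase-8 inhibitor core

The source may hold more compounds than are shown below. What is called first, only, known or untested is meant among the compounds shown, and "the series" means these compounds.

Compound 1 `O=C1C[C@H](NC(=O)[C@@H]2COC[C@@H]3C/C=C\C[C@H](NC(=O)c4ccc(C(F)(F)F)cc4)C(=O)N32)C(O)O1` shows the highest number of the three measured compounds in an assay on isolated protein for inhibition of Caspase-8 (Homo sapiens) (on this read-out higher numbers stand for weaker inhibition and lower numbers for stronger inhibition), giving 6450 nM. Compound 2 `O=C1C[C@H](NC(=O)[C@@H]2COC[C@@H]3CCCC[C@H](NC(=O)c4cc5ccccc5s4)C(=O)N32)C(O)O1` gives 429 nM in this assay, and compound 3 `O=C1C[C@H](NC(=O)[C@@H]2CN(C(=O)Nc3ccccc3)C[C@@H]3CCCC[C@H](NC(=O)c4ccccc4)C(=O)N32)C(O)O1` gives 601 nM; both gaps to compound 1 lie beyond the scatter. Compound 4 `O=C1C[C@H](NC(=O)[C@@H]2COC[C@@H]3C/C=C\C[C@H](NC(=O)c4ccc5ccccc5c4)C(=O)N32)C(O)O1` carries naphthalen-2-yl in place of 4-(trifluoromethyl)phenyl on a carbonyl carbon. Among the measured compounds shown here, no direct step between measured compounds isolates this change, so the expectation rests on the finding that both other acyl groups in this set reach lower numbers than compound 1. The step from compound 1 to compound 4 is expected to run toward stronger inhibition, modest in size, a 4.3-fold lower number from compound 1 to compound 4 (0.63 log units; beyond the scatter). Compound 4 is therefore estimated at 1500 nM, with a range from 400 nM to 5000 nM.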

Compound 4, half-maximal inhibitory concentration: 2590 nM
Compound 4: the middle estimate sits 1.7-fold (0.24 log units) below what was measured; the range from low to high includes it.
By their numbers in this assay, from the lowest: compounds 2 and 3 (each within the scatter of the next); then compound 4; then compound 1.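

Among the compounds shown here, at the carbonyl carbon bound to the amide-type nitrogen, exchanging 4-(trifluoromethyl)phenyl for naphthalen-2-yl in this assay gives a 2.5-fold lower number from compound 1 to compound 4 (0.40 log units; beyond the scatter) and is the only single-place step in this set. The exchange keeps the heavy-atom count but removes the fluorine and adds a second six-membered aromatic ring, and these differences cannot be separated here. Nothing available explains the stronger inhibition. For the compounds shown here, no pair shows whether this exchange would act alike on the cores of compound 2 or compound 3. Going by these compounds, how a 4-methoxyphenyl or a 4-carboxyphenyl would fare at this carbonyl carbon also remains open.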